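Dropping the chloro group from a fluorophenyl triazole

A few compounds are considered here, and "the series" means these few. Any claim that something is new, unique, unknown or untested is made for them only; others in the source may bear on it.

Compound 2 `Fc1ccc(-n2cc(COc3ccccc3-c3nc4ccccc4s3)nn2)cc1Cl` and compound 1 `FC(F)(F)C(F)(F)C(F)(F)C(F)(F)C(F)(F)C(F)(F)CCn1cc(COc2ccccc2-c2nc3ccccc3s2)nn1` were both tested in an ADME assay on MCF-10A cells (Homo sapiens) for cytotoxicity, read by MTT assay, with a stated time of 24 h; on this read-out higher numbers stand for weaker inhibition and lower numbers for stronger inhibition. Compound 2 gives 26300 nM, and compound 1 gives 35100 nM; the two numbers lie within the usual scatter of each other, so neither stands apart. Compound 3 `Fc1ccc(-n2cc(COc3ccccc3-c3nc4ccccc4s3)nn2)cc1` differs from compound 2 in one place: hydrogen in place of chloro on an aromatic carbon. Among the compounds with values here, no measured pair shows this change, so compound 3 is expected to stay close to compound 2, with a step of a 1.2-fold higher number from compound 2 to compound 3 (0.09 log units; within the scatter) that need not exceed the scatter. Compound 3 is estimated at 32000 nM, within 13000 nM to 80000 nM.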

Compound 3, half-maximal inhibitory concentration: 33300 nM
Compound 3: middle estimate off by 1.0-fold (0.02 log units), on the low side; low and high end bracket the measured number.
By their numbers in this assay, from the lowest: compounds 2, 3 and 1 (each within the scatter of the next).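

Replacing 3-chloro-4-fluorophenyl with 4-fluorophenyl gives the only one-place comparison among these compounds in this assay and the step is a 1.3-fold higher number from compound 2 to compound 3 (0.10 log units; within the scatter). The chloro group at this position can therefore be exchanged for hydrogen here without a difference that stands clear of the scatter. No measurement shown offers an explanation for this result. Going by these compounds, whether an amine or a carboxylic acid on the same aromatic carbon would give a different number remains open. So does the effect of replacing the fluoro group.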